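Trimming Ethoxy to Methoxy on the Shared Core

A few compounds are considered here, and "the series" means these few. Any claim that something is new, unique, unknown or untested is made for them only; others in the source may bear on it.

In a functional assay on CAL-51 cells (Homo sapiens) for antiproliferative activity, read by luminescence and CellTiter-Glo, with a stated time of 3 days (a lower number here means a stronger inhibitor, a higher number a weaker inhibitor), compound 1 `CCOc1cc(C(=O)N(C)C)ccc1Nc1nc(O[C@H]2CC[C@@](C)(O)CC2)c2cc[nH]c2n1` gives 26 nM. That lies within the scatter of compound 3 `CN(C)C(=O)c1ccc(Nc2nc(O[C@H]3CC[C@@](C)(O)CC3)c3cc[nH]c3n2)c(OCC(F)(F)F)c1` at 15 nM, and clearly lower than compound 2 `COc1cc(C(=O)N(C)C)ccc1Nc1nc(OC2CCCCC2)c2cc[nH]c2n1` at 190 nM. Compound 4 `COc1cc(C(=O)N(C)C)ccc1Nc1nc(O[C@H]2CC[C@@](C)(O)CC2)c2cc[nH]c2n1` has not been measured yet. It differs from compound 1 as follows: hydrogen in place of methyl on a saturated chain carbon bound to an oxygen on an aromatic ring. In words, hydrogen replaces methyl, turning ethoxy into methoxy. Among the compounds with values here, the only measured step at this place, with trifluoromethyl in place of methyl, is a 1.7-fold lower number from compound 1 to compound 3 (0.24 log units; within the scatter). A change at this place has therefore not yet moved the number beyond the scatter, and none is expected in this assay here. The expected step is a 1.1-fold higher number from compound 1 to compound 4 (0.03 log units; within the scatter). Compound 4 is estimated at 28 nM, with an expected range of 12 nM to 70 nM.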

Compound 4, half-maximal inhibitory concentration: 44 nM
Beside the measured number, compound 4's estimate is 1.6-fold (0.20 log units) below it, within the range that was stated.
By their numbers in this assay, from the lowest: compounds 3, 1 and 4 (each within the scatter of the next, the first and the last beyond it); then compound 2.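

In this assay, within the data shown here, trimming ethoxy to methoxy gives a 1.7-fold higher number from compound 1 to compound 4 (0.23 log units; within the scatter) and stays small, yet hydrogen and trifluoromethyl at this place do separate, with a 2.9-fold higher number from compound 3 to compound 4 (0.47 log units; beyond the scatter) as the first step here to pass the scatter. Compound 4 also isolates the other group: 4-hydroxy-4-methylcyclohexyl in place of cyclohexyl brings a 4.3-fold lower number from compound 2 to compound 4 (0.64 log units; beyond the scatter) with methoxy held fixed. Still open, as far as these compounds go, are a longer chain such as propoxy at this place, and an amine in place of the hydroxy of 4-hydroxy-4-methylcyclohexyl. Nothing shown here gives a measured reason for either step.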